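Oxime ether series: ethoxycarbonyl to methoxy on the benzyl ring

The source may hold more compounds than are shown below. What is called first, only, known or untested is meant among the compounds shown, and "the series" means these compounds.

Measured compounds:
compound 1 `CCOC(=O)c1ccc(CO/N=C/c2c(C)nn(C)c2Oc2ccc(Cl)cc2)cc1`: 33.9%
compound 2 `CCOC(=O)c1ccc(CO/N=C/c2c(C)nn(-c3ccccc3)c2Oc2ccc(Cl)cc2)cc1`: 12%

In a functional assay on MCF7 cells (Homo sapiens) for antiproliferative activity, tested at 1 uM (on this read-out lower numbers stand for less inhibition and higher numbers for more inhibition at the one concentration tested (going by the name of the read-out)), compound 1 gives 33.9%, the higher of the two numbers shown; the one measured step, a number 21.9 percentage points lower from compound 1 to compound 2 (beyond the scatter), concerns phenyl in place of methyl on an aromatic nitrogen. Compound 3 `COc1ccc(CO/N=C/c2c(C)nn(C)c2Oc2ccc(Cl)cc2)cc1` differs from compound 1 elsewhere: methoxy in place of ethoxycarbonyl on an aromatic carbon. No measured step touches this position, so nothing shown points to a direction, and the change from compound 1 is expected to stay within the scatter, a number 3.9 percentage points lower from compound 1 to compound 3 (within the scatter). Compound 3 is therefore estimated at 30% in this assay, with a range from 10% to 55%.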

Compound 3, a percentage reported as inhibition, at one concentration (the size of the read-out at that concentration, not a potency): 37%
Compound 3: middle estimate off by 7 percentage points, on the low side, within the range that was stated.
By their numbers in this assay, from the lowest: compound 2; then compounds 1 and 3 (each within the scatter of the next).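

Among these compounds, replacing ethoxycarbonyl with methoxy on this aromatic carbon gives the first reading at this position: in this assay, the change amounts to a number 3.1 percentage points higher from compound 1 to compound 3 (within the scatter). The ester is thus not needed for the inhibition level of compound 1 at this one concentration, and methoxy, with fewer heavy atoms and no double bond outside the aromatic rings, serves equally here. Nothing available offers a reason for this.

As far as these compounds go, whether a carboxylic acid, an amine or a longer alkoxy chain at this carbon would leave the number higher, lower or level remains open. Also open, from the compounds shown here alone, is whether methoxy gives the same result with phenyl on the aromatic nitrogen, as in compound 2.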